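Compound 3 and a small substituent swap

The source may report more compounds than this note shows. Statements on the series, on what has been measured and on what is new or still open speak of the compounds shown alone.

Compound 1 (`O=C(Nc1ccc(O)c2c(=O)cc(-c3ccccc3Cl)oc12)c1ccccc1`) gives 13000 nM
Compound 2 (`O=c1cc(-c2ccccc2Cl)oc2c(N3CCCC3)ccc(O)c12`) gives 9300 nM

In a functional assay on ID8 cells (Mus musculus) for antiproliferative activity (a higher number here means a weaker inhibitor, a lower number a stronger inhibitor), these two values lie within the scatter of each other, so compound 2 holds no place apart from compound 1. Compound 3 (`CS(=O)(=O)Nc1ccc(O)c2c(=O)cc(-c3ccccc3Cl)oc12`) differs from compound 2 by one change, (methanesulfonamido in place of pyrrolidin-1-yl on an aromatic carbon), with methanesulfonamido in place of pyrrolidin-1-yl on an aromatic carbon. Among the measured compounds shown here, the only measured step that bears on it is a 1.4-fold lower number from compound 1 to compound 2 (0.15 log units; within the scatter), a swap on that same carbon. No step beyond the scatter is therefore expected in this assay for this change. The estimated step is a 1.2-fold higher number from compound 2 to compound 3 (0.07 log units; within the scatter), which is small. Compound 3 is expected at 11000 nM, with an estimated range of 5000 nM to 25000 nM around that value.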

Compound 3, half-maximal inhibitory concentration: 16000 nM
Estimate against measurement, compound 3: 1.5-fold (0.16 log units) below; the measured number falls inside the stated range.
By their numbers in this assay, from the lowest: compounds 2, 1 and 3 (each within the scatter of the next).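

In this assay the methanesulfonamido group, the first without a ring on this aromatic carbon, gives a 1.7-fold higher number from compound 2 to compound 3 (0.24 log units; within the scatter). Methylsulfonyl in place of benzoyl on the same nitrogen gives a 1.2-fold higher number from compound 1 to compound 3 (0.09 log units; within the scatter), so all three groups at this position remain within the scatter of one another. No measured evidence explains this. On these data alone, whether a primary amine, a carboxylic acid or a longer alkyl chain on this carbon would produce a step beyond the scatter remains open.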